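This account rests on a few compounds, and the source may have more. Where it says the series, first, only, none or still open, it means among the compounds named here.

Measured compounds:
- compound 1, `CCc1cccc2c(OC)c(-c3occ(C)c3C(=O)OC)ccc12`: 2.2 ug/mL
- compound 2, `CCOc1c(-c2occ(C)c2C(=O)O)ccc2c(CC)cccc12`: > 10 ug/mL
- compound 3, `CCOc1c(-c2occ(C)c2CO)ccc2c(CC)cccc12`: > 10 ug/mL

In a functional assay on DU-145 cells (Homo sapiens) for cytotoxicity, read by MTT assay, with a stated time of 72 h (on this read-out lower numbers stand for an effect already at smaller amounts and higher numbers for an effect only at larger amounts of compound), compound 1 gives 2.2 ug/mL. Among the compounds with values here, this is the only actual number among the three results; the other two are limits. For compound 2 this assay reports only the limit > 10 ug/mL. For compound 3 it likewise reports only the limit > 10 ug/mL. The step from compound 2 to compound 3, a step that the two limits leave unreadable from compound 2 to compound 3, therefore cannot be sized, since both ends sit at the limit of > 10 ug/mL in this assay, at which 2 of the 3 values shown sit.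

Compound 4, `CCOCc1c(C)coc1-c1ccc2c(CC)cccc2c1OC`, has not been measured. It differs from compound 1 by ethoxymethyl in place of methoxycarbonyl on an aromatic carbon. Within the data shown here, no measured step covers this exact change, and the one measured step, from compound 2 to compound 3, is unreadable. Among the measured compounds shown here, what the data do show is that the only compound with a number is the one carrying the methoxycarbonyl group, while both compounds without it sit at the limit. On that basis a loss of potency is expected for compound 4, with the step of a 2.7-fold higher number from compound 1 to compound 4 (0.44 log units; beyond the scatter) taken as a guess rather than a reading. Compound 4 is thus estimated at 6 ug/mL, within 2 ug/mL to 15 ug/mL, with a real chance that this assay returns only a limit.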

Compound 4, concentration for half-maximal effect: > 10 ug/mL
Compound 4 gave a limit, no number (the forecaster's own chance of this, stated with the estimate: 40%); middle value at least 1.6-fold (0.22 log units) from the limit.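

In this assay, putting ethoxymethyl in place of methoxycarbonyl on the five-membered aromatic ring with 1 oxygen gives an at least 4.5-fold higher number from compound 1 to compound 4 (0.65 log units; beyond the scatter). Within the data shown here, this is the first change at this position that can be read on its own, as compounds 2 and 3 differ from compound 1 in more than one place, so their results could not tie the loss to this group alone. Compound 4 joins the compounds that give only a limit, so the step has a lower bound and no exact size: the limit of > 10 ug/mL in this assay, at which 3 of the 4 values shown sit.

The compounds shown include no ethyl ester or amide at this position, so it remains open whether other carbonyl groups would keep a measurable value. Whether the carbonyl itself matters, or the methyl ester as a whole, also remains unsettled.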